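Swapping the ring on the thiocarbonyl carbon of compound 2

The source may report more compounds than this note shows. Statements on the series, on what has been measured and on what is new or still open speak of the compounds shown alone.

Compound 1 `N/C(=N\NC(=S)N1CCOCC1)c1ccccn1`: 82.8%
Compound 2 `N/C(=N\NC(=S)N1CCSCC1)c1ccccn1`: 80.6%

Both measured compounds share one core and differ only in the ring attached to the thiocarbonyl carbon. In a functional assay on HeLa cells (Homo sapiens) for cytotoxicity, read by MTT assay, with a stated time of 72 h, tested at 30 uM (on this read-out lower numbers stand for less inhibition of growth and higher numbers for more inhibition of growth at the one concentration tested), compound 1 gives 82.8% and compound 2 gives 80.6%. The step of a number 2.2 percentage points lower from compound 1 to compound 2 (within the scatter) lies within the scatter, so compound 2 sits beside compound 1 on this read-out; the two numbers cannot be told apart.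

Compound 3 `N/C(=N\NC(=S)N1CCCCC1)c1ccccn1` has not yet been measured. Compared with compound 2 it carries piperidin-1-yl in place of thiomorpholin-4-yl on a thiocarbonyl carbon. Going by the values given here, the only measured step that bears on this change is the one from compound 1 to compound 2, where a ring of the same size at the same place was exchanged and the read-out moved by a number 2.2 percentage points lower from compound 1 to compound 2 (within the scatter). On that basis a further exchange of the ring at the thiocarbonyl carbon is expected to give no step beyond the scatter in either direction.

Compound 3 is therefore estimated at 80% in this assay, with a range from 65% to 92%. The expected step is a number 0.6 percentage points lower from compound 2 to compound 3 (within the scatter).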

Compound 3, percent growth inhibition at one concentration: 76.9%
The estimate for compound 3 lay 3.1 percentage points above the measured number, and the stated range covers the measured number.
By their numbers in this assay, from the lowest: compounds 3, 2 and 1 (each within the scatter of the next).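

At the thiocarbonyl carbon, the ring can now lose its sulfur without a readable effect: in this assay the exchange of thiomorpholin-4-yl for piperidin-1-yl gives a number 3.7 percentage points lower from compound 2 to compound 3 (within the scatter) and the exchange of morpholin-4-yl for piperidin-1-yl gives a number 5.9 percentage points lower from compound 1 to compound 3 (within the scatter) on the same read-out. Before this result, the only comparison was between two rings that each carry a further hetero atom, whereas piperidin-1-yl has only the one nitrogen and no hydrogen-bond acceptor, so the three six-membered rings now cannot be told apart at this place. Nothing available explains why these three rings read alike.

The rings shown are all six-membered and non-aromatic, so it remains open whether a five-membered pyrrolidin-1-yl ring, a piperazin-1-yl ring with its further nitrogen, or an open-chain dimethylamino group at the thiocarbonyl carbon would give a step beyond the scatter. From the compounds shown here alone, it also remains open whether these three compounds would separate at lower concentrations, since a reading at a single concentration cannot show that.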